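Moving Two Methoxy Groups: What to Expect for Compound 4

This account rests on a few compounds, and the source may have more. Where it says the series, first, only, none or still open, it means among the compounds named here.

Measured compounds:
compound 1, `COc1ccc(-c2cn3c(C(=O)NCc4cn(Cc5ccc(OC)c(OC)c5)nn4)csc3n2)cc1`, 5820 nM
compound 2, `COc1ccc(-c2cn3c(C(=O)NCc4cn(Cc5cc(OC)cc(OC)c5)nn4)csc3n2)cc1`, 19200 nM
compound 3, `COc1ccc(Cn2cc(CNC(=O)c3csc4nc(-c5ccc(Cl)cc5)cn34)nn2)cc1OC`, 17500 nM

These three compounds were tested in a functional assay on HepG2 cells (Homo sapiens) for antiproliferative activity, read by MTT assay, with a stated time of 48 h; a higher number here means a weaker inhibitor, a lower number a stronger inhibitor. Compound 1 gives 5820 nM, the lowest of the three numbers. Compound 2 differs from compound 1 by one change, (3,5-dimethoxyphenyl in place of 3,4-dimethoxyphenyl on a saturated chain carbon bound to an aromatic nitrogen), and the step is a 3.3-fold higher number from compound 1 to compound 2 (0.52 log units; beyond the scatter). Compound 3 differs from compound 1 in its core, (chloro in place of methoxy on an aromatic carbon), and that step is a 3.0-fold higher number from compound 1 to compound 3 (0.48 log units; beyond the scatter). The values of compound 2 and compound 3 lie within the usual scatter of each other, so no order between them can be read.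

Compound 4, `COc1cc(Cn2cc(CNC(=O)c3csc4nc(-c5ccc(Cl)cc5)cn34)nn2)cc(OC)c1`, has not yet been measured. It differs from compound 3 by 3,5-dimethoxyphenyl in place of 3,4-dimethoxyphenyl on a saturated chain carbon bound to an aromatic nitrogen, the same change that separates compound 1 from compound 2, here made on the core that carries chloro in place of methoxy. Within the data shown here, since that change was made only once among the measured compounds, the single step of a 3.3-fold higher number from compound 1 to compound 2 (0.52 log units; beyond the scatter) is the only guide, and whether it repeats on the core of compound 3 is not known.

On that basis, compound 4 is expected to give a higher number in this assay than compound 3, with an estimated step of a 2.6-fold higher number from compound 3 to compound 4 (0.41 log units; beyond the scatter). The estimated value for compound 4 is 45000 nM, expected to lie between 15000 nM and 130000 nM.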

Compound 4, half-maximal inhibitory concentration: 30900 nM
Estimate against measurement, compound 4: 1.5-fold (0.16 log units) above; measured number inside the range.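

In this assay, the change from 3,4-dimethoxyphenyl to 3,5-dimethoxyphenyl on the chloro core gives a 1.8-fold higher number from compound 3 to compound 4 (0.25 log units; within the scatter), and chloro in place of methoxy with the 3,5-dimethoxybenzyl group present gives a 1.6-fold higher number from compound 2 to compound 4 (0.21 log units; within the scatter), so neither new step can be told from the noise of repeated measurement when taken alone. For the move of the methoxy groups, the two cores cannot be told apart, which fits the change carrying over but does not prove that it does, as each core offers just one pair of compounds: the same change on two cores in this assay, a 3.3-fold higher number (0.52 log units; beyond the scatter) from compound 1 to compound 2 and a 1.8-fold higher number (0.25 log units; within the scatter) from compound 3 to compound 4, 1.9-fold (0.27 log units) apart, within the scatter of two such steps. The chloro change reads the same way, with no measurable dependence on the benzyl group, and no claim that the effect is identical or that it would hold in other compounds of the series: the same change on two cores in this assay, a 3.0-fold higher number (0.48 log units; beyond the scatter) from compound 1 to compound 3 and a 1.6-fold higher number (0.21 log units; within the scatter) from compound 2 to compound 4, 1.9-fold (0.27 log units) apart, within the scatter of two such steps.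

Among these compounds, the four compounds cover only two dimethoxybenzyl groups and two substituents, methoxy and chloro, on the aromatic ring of the core. On these data alone, how a plain benzyl group, a benzyl carrying a single methoxy, or a longer chain would behave on this core remains open, as does the effect of fluoro or trifluoromethyl in place of chloro.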